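This account rests on a few compounds, and the source may have more. Where it says the series, first, only, none or still open, it means among the compounds named here.

Notes on a series tested in a functional assay on A549 cells (Homo sapiens) for cytotoxicity, read by MTT assay, with a stated time of 48 h; on this read-out lower numbers stand for stronger inhibition and higher numbers for weaker inhibition. Compound 1, `C=CC(=C)CC[C@@H]1[C@@]2(C)CCC[C@](C)(COC(=O)/C=C\c3ccc(O)cc3)[C@@H]2CC[C@@]1(C)O`, carries a 2-(4-hydroxyphenyl)ethenyl ester on its core; in this assay compound 1 gives 17100 nM. Compound 2, `C=CC(=C)[C@@H](O)C[C@H]1C(=C)CC[C@@H]2[C@]1(C)CCC[C@]2(C)C(=O)O`, is a carboxylic acid relative of the same core; in this assay compound 2 returns only a limit of the assay, > 40000 nM, so no number stands for it. Going by the values given here, compound 1 therefore holds the only numerical value in the set, the other entry being a limit, (the limit of > 40000 nM in this assay, at which 1 of the 2 values shown sits).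

Compound 3, `C=CC(=C)CC[C@@H]1[C@@]2(C)CCC[C@](C)(COC(=O)/C=C\c3ccc(O)c(OC)c3)[C@@H]2CC[C@@]1(C)O`, differs from compound 1 in one place: methoxy in place of hydrogen on an aromatic carbon. Among the compounds with values here, no pair of measured compounds differs only in this way, so the size of this step has no measured anchor. The change places one methoxy group on the six-membered aromatic ring of carbon only, and with nothing in the measured set to gauge it, the expected step in this assay is taken as none beyond the scatter, a 1.1-fold lower number from compound 1 to compound 3 (0.06 log units; within the scatter). Compound 3 is thus expected to give about 15000 nM in this assay, with a range from 6000 nM to 38000 nM.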

Compound 3, half-maximal inhibitory concentration: 17300 nM
Beside the measured number, compound 3's estimate is 1.2-fold (0.06 log units) below it; the range from low to high includes it.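

In this assay, going by these compounds alone, methoxy in place of hydrogen on an aromatic carbon, ortho to a hydroxy group and meta to a large group, gives a 1.0-fold higher number from compound 1 to compound 3 (0.01 log units; within the scatter), which is the first measured anchor for this change. At this position, then, going from 4-hydroxyphenyl to 4-hydroxy-3-methoxyphenyl leaves the read-out in this assay within the scatter, and compound 3 with 17300 nM stands on the same level as compound 1. Nothing in the available data offers an explanation for this flat step.

Still open, as far as these compounds go, is whether a different group on this aromatic carbon, such as an ethoxy group, an amine or a carboxylic acid, would move the number beyond the scatter, and whether the hydroxy group itself contributes to the value. Compound 2 stands at > 40000 nM, which is a limit of the assay, and it differs from compound 1 in more than one place, so it gives no reading on the role of this position.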